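This account rests on a few compounds, and the source may have more. Where it says the series, first, only, none or still open, it means among the compounds named here.

Compound 1 `COc1ccc(S(=O)(=O)Nc2ccc(-c3nc4ccccc4o3)cc2)cc1` carries a sulfonamide on a shared core. In an assay on cells for inhibition of HSP60/HSP10 (Homo sapiens), with a stated time of 60 min (on this read-out lower numbers stand for stronger inhibition and higher numbers for weaker inhibition), compound 1 gives only a limit, > 100000 nM, so no number is known for it. Two related compounds do give numbers in this assay: compound 2 `CS(=O)(=O)Nc1ccc(-c2nc3cc(NS(=O)(=O)c4ccc(Cl)s4)ccc3o2)cc1` gives 43000 nM, and compound 3 `O=S(=O)(Nc1ccc2oc(-c3ccccc3)nc2c1)c1ccc(F)c(C(F)(F)F)c1` gives 69000 nM. Every value shown here is weak, and one of the three sits at the limit (the limit of > 100000 nM in this assay, at which 1 of the 3 values shown sits).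

Compound 4 `O=S(=O)(Nc1ccc(-c2nc3ccccc3o2)cc1)c1ccc(Cl)cc1` has not yet been measured in this assay. It differs from compound 1 in one place (chloro in place of methoxy on an aromatic carbon), a change that, cut one bond further out, reads 4-methoxyphenyl to 4-chlorophenyl. Within the data shown here, no measured pair shows what this change does here, and the starting point is itself a limit, so the step can only be guessed. The step from compound 1 to compound 4 is expected to be small, at an at least 1.1-fold lower number from compound 1 to compound 4 (0.04 log units; that floor lies within the scatter), with no clear direction beyond the scatter. Compound 4 is therefore expected to give about 90000 nM, most likely between 25000 nM and 300000 nM, and it may well remain at the limit.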

Compound 4, half-maximal inhibitory concentration: 61000 nM
Estimate against measurement, compound 4: 1.5-fold (0.17 log units) above; low and high end bracket the measured number.
By their numbers in this assay, from the lowest: compounds 2, 4 and 3 (each within the scatter of the next). At a limit, above all of these: compound 1.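

In this assay compound 1 gives > 100000 nM and this is a limit, not a number. Compound 4, with chloro in place of methoxy on the same aromatic carbon, gives 61000 nM as a true number, so a group at this place can now be read on the scale of the assay. From the compounds shown here alone, the change amounts to an at least 1.6-fold lower number from compound 1 to compound 4 (0.21 log units; that floor lies within the scatter) and that figure is only a floor, so the real size of the step stays unknown.

The compounds shown leave open what an amine, a carboxylic acid or a longer chain would give on this aromatic carbon. Among these compounds, they also leave open whether chloro in place of methoxy would give a similar step on another core, since only this one pair shows the change.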